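Series notes: from compound 1 to compound 4

A few compounds are considered here, and "the series" means these few. Any claim that something is new, unique, unknown or untested is made for them only; others in the source may bear on it.

Compound 1 `O=C1/C(=C\c2c(Cl)cccc2Cl)c2ccccc2N1c1c(Cl)cccc1Cl` is the reference point of this set. In a functional assay on B16-F10 cells (Homo sapiens) for cytotoxicity against B16-F10 (Mus musculus), read by MTT assay, with a stated time of 72 h (a lower number here means that less compound is needed, a higher number that more compound is needed for the effect), compound 1 gives > 100 ug/mL, which is a limit of the assay and not a number. Compound 3 `O=C1/C(=C\c2cccc(Oc3ccccc3)c2)c2ccccc2N1c1c(Cl)cccc1Cl` carries a 3-phenoxyphenyl group in the same position and in this assay compound 3 gives > 100 ug/mL, again a limit rather than a number. Compound 2 `O=C1/C(=C\c2cc3ccccc3nc2Cl)c2ccccc2N1c1c(Cl)cccc1Cl` is also part of the series, but in this assay compound 2 gives "not determined" (no result reported). Within the data shown here, the standing of compound 1 is therefore described only by the limit of > 100 ug/mL in this assay, at which 2 of the 3 values shown sit, so no measured step between neighbouring compounds is available and no direction has been demonstrated.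

Compound 4 `CN(C)c1ccc(/C=C2\C(=O)N(c3c(Cl)cccc3Cl)c3ccccc32)cc1` differs from compound 1 by a single replacement: 4-(dimethylamino)phenyl in place of 2,6-dichlorophenyl on a double-bonded chain carbon bound to a double-bonded ring carbon. With both measured neighbours sitting at the limit, the expectation for the step from compound 1 to compound 4 in this assay is stated cautiously as an at least 1.6-fold lower number from compound 1 to compound 4 (0.22 log units; that floor lies within the scatter), a modest gain at most, not clearly beyond the usual scatter. Compound 4 is accordingly estimated at 60 ug/mL in this assay, with a plausible range from 15 ug/mL to 200 ug/mL, and a substantial chance that only a limit is reported again.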

Compound 4, concentration for half-maximal effect: > 100 ug/mL
Compound 4 gave a limit, no number; the forecaster's own chance of this, stated with the estimate: 50%; middle value at least 1.6-fold (0.22 log units) away from the limit.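

In this assay compound 4 gives > 100 ug/mL, a limit of the assay and not a number. Among these compounds, compound 1 also stands at a limit, so no step from compound 1 to compound 4 can be read. The compounds shown leave open whether any group on that double-bonded chain carbon yields an actual number in this assay: the limit of > 100 ug/mL in this assay, at which 3 of the 4 values shown sit.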